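The source may report more compounds than this note shows. Statements on the series, on what has been measured and on what is new or still open speak of the compounds shown alone.

Going by the values given here, compound 3 `Cc1cccc(C(=O)NCN2CCC(c3cccc[n+]3[O-])CC2)c1` stands at the top of the three numbers known in a functional assay on HEK293 cells for agonist activity at D(4) dopamine receptor (Homo sapiens), read by FLIPR (a lower number here means that less compound is needed, a higher number that more compound is needed for the effect), with a value of 89 nM. Compound 1 `Cc1cccc(C(=O)NCN2CCC(c3nccs3)CC2)c1` gives 9.8 nM in this assay, and compound 2 `Cc1cccc(C(=O)NCN2CCC(c3ccccn3)CC2)c1` gives 9 nM; the step of a 1.1-fold lower number from compound 1 to compound 2 (0.04 log units; within the scatter) stays within the scatter, while a 9.1-fold higher number from compound 1 to compound 3 (0.96 log units; beyond the scatter) and a 9.9-fold higher number from compound 2 to compound 3 (1.00 log units; beyond the scatter) both lie beyond it. Compound 4 `COc1ccccc1C1CCN(CNC(=O)c2cccc(C)c2)CC1` differs from compound 3 by the change (a group of 8 heavy atoms (7 carbon, 1 oxygen; one six-membered aromatic ring of carbon only) in place of a group of 7 heavy atoms (5 carbon, 1 nitrogen, 1 oxygen; one six-membered aromatic ring with 1 hetero atom), on a saturated ring carbon). The two steps into compound 3 bear directly on this move: each time a neutral aromatic ring on that saturated ring carbon was replaced by the ring carrying the oxygen on its nitrogen, the number rose roughly in the same measure. Going back to a neutral aromatic ring of carbon only, he therefore expects the number to fall again, by a step of about a 7.4-fold lower number from compound 3 to compound 4 (0.87 log units; beyond the scatter), bringing compound 4 close to where compound 1 and compound 2 sit. His estimate for compound 4 in this assay is 12 nM, with a range from 4 nM to 40 nM.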

Compound 4, half-maximal effective concentration: 206 nM
Estimate against measurement, compound 4: 17-fold (1.23 log units) below, and the stated range ends below it.
By their numbers in this assay, from the lowest: compounds 2 and 1 (each within the scatter of the next); then compound 3; then compound 4.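

In this assay, the 2-methoxyphenyl group on this saturated ring carbon gives the highest number of the series, above the ring carrying the oxygen on its nitrogen (a 2.3-fold higher number from compound 3 to compound 4 (0.36 log units; beyond the scatter)) and well above pyridin-2-yl (a 23-fold higher number from compound 2 to compound 4 (1.36 log units; beyond the scatter)) and 1,3-thiazol-2-yl (a 21-fold higher number from compound 1 to compound 4 (1.32 log units; beyond the scatter)). Removing the ring nitrogen and its oxygen therefore did not restore the lower numbers, so an aromatic ring at this position does not by itself give them. Among the four compounds, the two groups containing oxygen give the higher numbers, and the two without it give the lower numbers.

These compounds cannot separate the methoxy group from the carbon-only ring, which a plain phenyl or a 2-methylphenyl group would address. Nothing measured here explains why the 2-methoxyphenyl group gives the highest number.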